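A few compounds are considered here, and "the series" means these few. Any claim that something is new, unique, unknown or untested is made for them only; others in the source may bear on it.

Measured compounds:
compound 1, `CN1CC(S(=O)(=O)c2ccc3c(c2)nc(CC(C)(C)C)n3CCOC(F)(F)F)C1`, 86 mL/min/kg
compound 2, `CN1CC(S(=O)(=O)c2ccc3c(c2)nc(CC(C)(C)C)n3CC(C)(C)O)C1`, 13 mL/min/kg

Among the measured compounds shown here, in an ADME assay (liver) for metabolic stability, with Liver microsome (Homo sapiens) as the target, using microsomes (a higher number here means faster removal of the compound, a lower number slower removal), compound 2 gives 13 mL/min/kg, the lowest of the two numbers so far, while compound 1 gives 86 mL/min/kg. For the measured compounds named here, the one measured step, a 6.6-fold lower number from compound 1 to compound 2 (0.82 log units; beyond the scatter), swapped the group on the saturated chain carbon bound to the aromatic nitrogen and moved the number well beyond the scatter. Compound 3, `CN1CC(S(=O)(=O)c2ccc3c(c2)nc(CC(C)(C)C)n3CC2(O)CCOCC2)C1`, is not yet measured. It differs from compound 2 by 4-hydroxyoxan-4-yl in place of 1-hydroxy-1-methylethyl on a saturated chain carbon bound to an aromatic nitrogen; cut one bond further out, the change reads 2-hydroxy-2-methylpropyl to (4-hydroxyoxan-4-yl)methyl. Going by the values given here, no measured step covers a change of this kind, in which the hydroxyl stays and the chain end is closed into a ring, so the step from compound 1 to compound 2 offers no direct guide. The expected step of a 1.1-fold lower number from compound 2 to compound 3 (0.03 log units; within the scatter) is therefore within the scatter, with no clear direction. Compound 3 is expected to give about 12 mL/min/kg, from 6 mL/min/kg to 26 mL/min/kg.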

Compound 3, clearance: 12 mL/min/kg
Compound 3: middle estimate and measured number agree at the digits printed; low and high end bracket the measured number.
By their numbers in this assay, from the lowest: compounds 3 and 2 (each within the scatter of the next); then compound 1.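

In this assay, the ring-bearing 4-hydroxyoxan-4-yl in place of 1-hydroxy-1-methylethyl gives a 1.1-fold lower number from compound 2 to compound 3 (0.03 log units; within the scatter) and so shows that this position on the saturated chain carbon bound to an aromatic nitrogen accepts the larger group with no change beyond the scatter. The second new step, a 7.2-fold lower number from compound 1 to compound 3 (0.86 log units; beyond the scatter) with 4-hydroxyoxan-4-yl in place of (trifluoromethoxy)methyl, means that two different hydroxyl-bearing groups now stand apart from compound 1, not just one. Nothing available here speaks to the cause of either step.

The compounds shown leave open whether the hydroxyl itself is what separates these groups from (trifluoromethoxy)methyl, since a methoxy group, an amine or a carboxylic acid at this place would be needed to tell. They also leave open what the ring oxygen contributes, which 1-hydroxycyclohexyl, an all-carbon ring, could address.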